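The source may report more compounds than this note shows. Statements on the series, on what has been measured and on what is new or still open speak of the compounds shown alone.

Measured compounds in a functional assay on Hep 3B2 cells (Homo sapiens) for cytotoxicity, read by MTT assay; a lower number here means a stronger inhibitor, a higher number a weaker inhibitor:

- compound 1, `CCCCOc1ccc(O)c(C(=O)/C=C/c2ccc(C)s2)c1`: 91700 nM
- compound 2, `CCCCCOc1ccc(O)c(C(=O)/C=C/c2ccc(C)s2)c1`: 112000 nM
- compound 3, `CCOc1ccc(OC)cc1C(=O)/C=C/c1ccc(C)s1`: 200 nM

Compound 1 and compound 2 share a core and differ in one place, (methyl in place of hydrogen on a saturated chain carbon, four bonds along the chain from an oxygen on an aromatic ring). Across this pair the number moves by a 1.2-fold higher number from compound 1 to compound 2 (0.09 log units; within the scatter), so within this assay the two are not separated.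

Compound 3 sits on a different core. Its number is the lowest of the three, and its steps to compound 1 and to compound 2 both lie beyond the scatter. How the core of compound 3 differs from the core of compound 1 is not broken down here.

Compound 4, `CCCOc1ccc(OC)cc1C(=O)/C=C/c1ccc(C)s1`, has not yet been measured. It derives from compound 3 by methyl in place of hydrogen on a saturated chain carbon, two bonds along the chain from an oxygen on an aromatic ring. For the measured compounds named here, this is the same kind of change as the one from compound 1 to compound 2, but not the same: there the methyl enters four bonds along the chain from an oxygen on an aromatic ring, here it enters two bonds along the chain from an oxygen on an aromatic ring, and the two cores differ in a way that is not broken down here.

Going by the values given here, the only measured precedent for adding one chain carbon is the pair compound 1 to compound 2, whose step of a 1.2-fold higher number from compound 1 to compound 2 (0.09 log units; within the scatter) is within the scatter. On that basis the step from compound 3 to compound 4 is expected to be small, about a 1.3-fold higher number from compound 3 to compound 4 (0.10 log units; within the scatter). Compound 4 is therefore estimated at 250 nM, with a range from 80 nM to 800 nM, the width reflecting that the precedent comes from a different core and a different place on the chain.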

Compound 4, half-maximal inhibitory concentration: 7000 nM
Beside the measured number, compound 4's estimate is 28-fold (1.45 log units) below it, outside the stated range (above it).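

In this assay, the ethoxy to propoxy change gives a 35-fold higher number from compound 3 to compound 4 (1.54 log units; beyond the scatter), so on the core of compound 3 this single added carbon separates the two compounds clearly. Adding one chain carbon therefore does not carry a fixed step from one core to the other in this series, and the step seen on the core of compound 1 does not predict the size of the step on the core of compound 3: the same change on two cores in this assay, a 1.2-fold higher number (0.09 log units; within the scatter) from compound 1 to compound 2 and a 35-fold higher number (1.54 log units; beyond the scatter) from compound 3 to compound 4, 29-fold (1.46 log units) apart, beyond the scatter of two such steps

This does not show why the two steps part, since the pairs differ both in the core and in the place on the chain, two bonds along the chain from an oxygen on an aromatic ring in one and four bonds along in the other, and two pairs cannot separate these two differences.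

Open, going by these compounds, is whether the ethoxy to propoxy change gives a comparable step on the core of compound 1, which would compare the two cores at one place on the chain. Also open, on these data alone, is how the core of compound 3 responds to a longer chain, or to a branched isopropoxy group or an amine at the chain end, and so whether the rise continues, levels off or reverses.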